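A few compounds are considered here, and "the series" means these few. Any claim that something is new, unique, unknown or untested is made for them only; others in the source may bear on it.

Working notes on the series. In a functional assay on thoracic aorta (Rattus norvegicus, strain Wistar), with a stated time of 15 min (on this read-out lower numbers stand for an effect already at smaller amounts and higher numbers for an effect only at larger amounts of compound), compound 1 `CCOc1ccc(Cl)cc1C(C)NC(=O)NS(=O)(=O)c1ccc(C)cc1` gives > 300000 nM, which is a limit of the assay and not a number. For the measured compounds named here, compound 2 `COc1ccc(Cl)cc1C(C)NC(=O)N(C)S(=O)(=O)c1ccc(C)cc1` gives 13800 nM in this assay, and this is the only true number available so far. Compound 3 `CCOc1ccc(Cl)cc1C(C)NC(=O)N(C)S(=O)(=O)c1ccc(C)cc1` is the next to be read. Its difference from compound 2 is methyl in place of hydrogen on a saturated chain carbon bound to an oxygen on an aromatic ring, which turns methoxy into ethoxy. Going by the values given here, no measured pair shows this change on its own, so its size in this assay can only be estimated. The expectation therefore rests on compound 2 at 13800 nM and on the modest extent of the change. No shift beyond the usual scatter is expected in either direction, and the estimate is a 1.1-fold lower number from compound 2 to compound 3 (0.03 log units; within the scatter). A reading of compound 3 as a limit of the assay is possible but not expected. For compound 3 the estimated value is 13000 nM, with an expected range from 4000 nM to 45000 nM.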

Compound 3, half-maximal effective concentration: 12200 nM
Compound 3: middle estimate off by 1.1-fold (0.03 log units), on the high side, within the range that was stated.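

In this assay, for the compounds shown here, methyl in place of hydrogen on a saturated chain carbon bound to an oxygen on an aromatic ring, which turns methoxy into ethoxy, gives a 1.1-fold lower number from compound 2 to compound 3 (0.05 log units; within the scatter), the first direct reading of this change, and it shows that ethoxy and methoxy cannot be told apart at this place. Going by these compounds alone, compound 3 also provides the first pair that differs at the amide-type nitrogen, where methyl in place of hydrogen gives an at least 24-fold lower number from compound 1 to compound 3 (1.39 log units; beyond the scatter), so in the ethoxy compounds the read-out depends strongly on this one place. The size of that step remains a lower bound, as compound 1 stands at a limit of the assay and not at a number: the limit of > 300000 nM in this assay, at which 1 of the 3 values shown sits.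

The compounds shown leave open whether the chain on the oxygen can grow further, for instance to a propyl or a longer chain, or can carry an amine or a carboxylic acid at its end. They also leave open whether ethyl on the amide-type nitrogen would serve as methyl does, and how large the methyl step would be in the methoxy compounds.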